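A few compounds are considered here, and "the series" means these few. Any claim that something is new, unique, unknown or untested is made for them only; others in the source may bear on it.

Measured compounds:
Compound 1 `CC(=O)OC[C@H]1O[C@@H](n2cc(CN3C(=O)/C(=C/c4ccc(C)cc4)c4ccccc43)nn2)[C@H](OC(C)=O)[C@@H](OC(C)=O)[C@@H]1OC(C)=O` gives 9300 nM in a functional assay on DU-145 cells (Homo sapiens) for cytotoxicity, read by sulforhodamine B assay, with a stated time of 48 h; on this read-out higher numbers stand for weaker inhibition and lower numbers for stronger inhibition.
Compound 2 `CC(=O)OC[C@H]1O[C@@H](n2cc(CN3C(=O)/C(=C/C=C/c4ccccc4)c4ccccc43)nn2)[C@H](OC(C)=O)[C@@H](OC(C)=O)[C@@H]1OC(C)=O` gives 17100 nM in this assay.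
Compound 3 `CC(=O)OC[C@H]1O[C@@H](n2cc(CN3C(=O)/C(=C\c4ccc(N(C)C)cc4)c4ccccc43)nn2)[C@H](OC(C)=O)[C@@H](OC(C)=O)[C@@H]1OC(C)=O` gives 10100 nM in this assay.

Compound 3 stands second highest of these three numbers, within the scatter of both compound 1 and compound 2. Compound 4 `CC(=O)OC[C@H]1O[C@@H](n2cc(CN3C(=O)/C(=C/c4ccc(N(C)C)cc4)c4ccccc43)nn2)[C@H](OC(C)=O)[C@@H](OC(C)=O)[C@@H]1OC(C)=O` differs from compound 3 only in this way: the two compounds have the same atoms and bonds and differ only in configuration as drawn: 1 of 6 stereo elements differ; a double bond is drawn Z in compound 3 and E in compound 4. Among the measured compounds shown here, the one measured step, a 1.8-fold higher number from compound 1 to compound 2 (0.26 log units; within the scatter), swaps a group rather than flipping a double bond, so it does not bear directly on this change. For the measured compounds named here, no measured pair shows what the Z-to-E flip does, and the three measured numbers sit within the scatter of one another, so no step beyond the scatter is expected in this assay. The expected change is a 1.1-fold higher number from compound 3 to compound 4 (0.04 log units; within the scatter). Compound 4 is estimated at 11000 nM, ranging from 3000 nM to 40000 nM.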

Compound 4, half-maximal inhibitory concentration: 11200 nM
Compound 4: middle estimate off by 1.0-fold (0.01 log units), on the low side; the range from low to high includes it.
By their numbers in this assay, from the lowest: compounds 1, 3, 4 and 2 (each within the scatter of the next).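

Flipping the double bond from Z to E gives a 1.1-fold higher number from compound 3 to compound 4 (0.04 log units; within the scatter) in this assay, so for this pair the drawn geometry at that double bond shifts the number no more than repeat measurements would, and the comparison is clean: the fact that compounds 3 and 4 differ only in the configuration as drawn. The group swaps also stay within the scatter: a 1.5-fold lower number from compound 2 to compound 4 (0.18 log units; within the scatter), with 4-(dimethylamino)phenyl in place of 2-phenylethenyl, and a 1.2-fold higher number from compound 1 to compound 4 (0.08 log units; within the scatter), with dimethylamino in place of methyl.

Still open, on these data alone, is whether a carboxylic acid in place of dimethylamino on that aromatic carbon would separate the Z and E forms.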